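The compounds below may be only part of what the source reports. "The series", "measured", "known", "first", "only" and "open" are said of these compounds alone.

Measured so far:
compound 1, `CC(C(=O)N1CCN(c2ccccc2)CC1)N1C(=O)CCC1=O`, 50%
compound 2, `CCC(C(=O)N1CCN(c2ccc(F)cc2)CC1)N1C(=O)CCC1=O`, 25%

In a functional assay on the whole organism (strain Swiss) with Mus musculus as the target, in the maximal electroshock model, with a stated time of 1 h, at a dose of 300 mg/kg by the intraperitoneal route (on this read-out lower numbers stand for a weaker effect and higher numbers for a stronger effect at the one dose given), compound 1 gives 50%, whereas compound 2 gives 25%, the lowest of the two numbers shown, standing a gap below compound 1 that goes beyond the usual scatter. Compound 1 and compound 2 differ from each other in two places, so their two values show only that difference and not a single step. Compound 3, `CC(C(=O)N1CCN(c2ccc(F)cc2)CC1)N1C(=O)CCC1=O`, has not yet been measured in this assay. It differs from compound 2 by hydrogen in place of methyl on a saturated chain carbon, two bonds along the chain from an amide-type nitrogen in a ring and a carbonyl carbon. Compound 3 thus carries the methyl of compound 1 together with the fluorine of compound 2. Among the compounds with values here, no single-change step is known here, so a moderate rise is expected, a number 15 percentage points higher from compound 2 to compound 3 (beyond the scatter), though not with confidence beyond the scatter. Compound 3 is expected to give 40%, within a range from 15% to 65%.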

Compound 3, a percentage reported as activity, at one dose (the size of the read-out at that dose, not a potency): 25%
The estimate for compound 3 lay 15 percentage points above the measured number, and the stated range covers the measured number.
By their numbers in this assay, from the lowest: compounds 2 and 3 (each within the scatter of the next); then compound 1.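

In this assay the change from ethyl to methyl on the saturated chain carbon gives no change at the digits printed from compound 2 to compound 3 (within the scatter), so with the fluoro group in place, this one-carbon difference in the chain does not register at this dose. Fluoro in place of hydrogen on an aromatic carbon can now be read as a single change, giving a number 25 percentage points lower from compound 1 to compound 3 (beyond the scatter), which the earlier pair, differing in two places, could not show. Nothing at hand explains either step.

The compounds shown leave open whether ethyl and methyl would also read alike on the core without fluoro, as that comparison rests on this one pair. They also leave open how a longer chain such as propyl at this carbon, or chloro or methoxy in place of fluoro on the aromatic carbon, would read in this assay.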